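This account rests on a few compounds, and the source may have more. Where it says the series, first, only, none or still open, it means among the compounds named here.

Compound 1 `CC(C)[C@H](NC(=O)COc1cccc2ccccc12)C(=O)N[C@@H](CC(=O)O)C(=O)COc1cc(C(F)(F)F)n(C)n1`, compound 2 `COC(=O)c1cc(OCC(=O)[C@H](CC(=O)O)NC(=O)[C@@H](NC(=O)COc2cccc3ccccc23)C(C)C)no1` and compound 3 `CC(C)[C@H](NC(=O)COc1cccc2ccccc12)C(=O)N[C@@H](CC(=O)O)C(=O)COn1nnc2ccccc21` share one core and differ only in the aromatic group attached through an oxygen on a saturated carbon. In a functional assay on Jurkat cells (Homo sapiens) for inhibition (a higher number here means a weaker inhibitor, a lower number a stronger inhibitor), compound 1 gives 46000 nM. In this assay compound 2 gives 71000 nM, and the pair shows a 1.5-fold higher number from compound 1 to compound 2 (0.19 log units; within the scatter). Compound 3 reaches only the limit of the assay, > 200000 nM, so its true number is not known. The steps leading to it are an at least 4.3-fold higher number from compound 1 to compound 3 (0.63 log units; beyond the scatter) and an at least 2.8-fold higher number from compound 2 to compound 3 (0.44 log units; beyond the scatter); both exchanges away from a five-membered aromatic ring with 2 hetero atoms weakened inhibition beyond the scatter. Compound 4 `CC(C)[C@H](NC(=O)COc1cccc2ccccc12)C(=O)N[C@@H](CC(=O)O)C(=O)COc1nccc(C(F)(F)F)n1` has not yet been measured. Its change from compound 3 is a group of 10 heavy atoms (5 carbon, 2 nitrogen, 3 fluorine; one six-membered aromatic ring with 2 hetero atoms) in place of a group of 9 heavy atoms (6 carbon, 3 nitrogen; one five-membered aromatic ring with 3 hetero atoms, one six-membered aromatic ring of carbon only), on an oxygen on a saturated carbon. This moves back towards the kind of trifluoromethyl-bearing group carried by compound 1, which gives 46000 nM in this assay. In this assay the step is therefore expected to be an at least 2.8-fold lower number from compound 3 to compound 4 (0.45 log units; beyond the scatter). The expected value for compound 4 is 70000 nM, likely between 25000 nM and 200000 nM.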

Compound 4, half-maximal inhibitory concentration: > 200000 nM
Compound 4: only a limit was reported; the forecaster's own chance of this, stated with the estimate: 30%; at least 2.8-fold (0.45 log units) between middle value and limit.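

In this assay, carrying a trifluoromethyl group is not enough at this position: with 4-(trifluoromethyl)pyrimidin-2-yl on the oxygen, the result is an at least 4.3-fold higher number from compound 1 to compound 4 (0.63 log units; beyond the scatter) and an at least 2.8-fold higher number from compound 2 to compound 4 (0.44 log units; beyond the scatter). Compound 1 and compound 4 both hold a trifluoromethyl group, so among these four compounds, only the two with a five-membered aromatic ring with 2 hetero atoms, compound 1 and compound 2, give a number inside the range of the assay. The step between compound 3 and compound 4 cannot be read because both are limits, not numbers: the limit of > 200000 nM in this assay, at which 2 of the 4 values shown sit.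

Still open, on these data alone, is whether the five-membered ring or the group on it matters more, and a 1-methyl-1H-pyrazol-3-yl group without trifluoromethyl would separate the two. A plain phenyl group on the same oxygen would test whether any ring nitrogen is needed at all.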